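Working notes: aryl variation on the ring nitrogen, compound 3 outlook

A few compounds are considered here, and "the series" means these few. Any claim that something is new, unique, unknown or untested is made for them only; others in the source may bear on it.

Measured so far:
compound 1 `Fc1cccc(Nc2nc(-c3cccc(F)c3)nc3ccc(F)cc23)c1` – 43100 nM
compound 2 `Fc1cccc(-c2nc(Nc3ccc(Cl)cc3)c3cc(F)ccc3n2)c1` – 45700 nM

In a functional assay on HL-60 cells (Homo sapiens) for cytotoxicity, read by MTT assay, with a stated time of 48 h (on this read-out lower numbers stand for stronger inhibition and higher numbers for weaker inhibition), compound 1 gives 43100 nM. In the same assay compound 2 gives 45700 nM. For the measured compounds named here, on these two numbers compound 2 stands beside compound 1: the only step in hand, a 1.1-fold higher number from compound 1 to compound 2 (0.03 log units; within the scatter), lies within the scatter, so neither compound is separated from the other on this read-out.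

Compound 3 `Oc1cccc(Nc2nc(-c3cccc(F)c3)nc3ccc(F)cc23)c1` is not yet measured. It differs from compound 2 by 3-hydroxyphenyl in place of 4-chlorophenyl on a nitrogen on an aromatic ring. Going by the values given here, the single measured step, a 1.1-fold higher number from compound 1 to compound 2 (0.03 log units; within the scatter), concerns the same position, an exchange of one aryl group for another on that nitrogen, and it produced no movement beyond the scatter. Among the compounds with values here, no measured step introduces a hydroxyl at this position, so the data give no basis for a shift in either direction. The expected step from compound 2 to compound 3 is therefore a 1.1-fold lower number from compound 2 to compound 3 (0.06 log units; within the scatter), none beyond the scatter. Compound 3 is expected to give about 40000 nM in this assay, with a range of 15000 nM to 110000 nM.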

Compound 3, half-maximal inhibitory concentration: > 50000 nM
Compound 3: only a limit was reported (the forecaster's own chance of this, stated with the estimate: 10%); middle value at least 1.2-fold (0.09 log units) from the limit.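

In this assay compound 3 gives > 50000 nM, which is a limit of the assay and not a number; the reading of this result rests on that: the limit of > 50000 nM in this assay, at which 1 of the 3 values shown sits.

Two steps carry this limit, an at least 1.0-fold higher number from compound 2 to compound 3 (0.03 log units; that floor lies within the scatter) with 3-hydroxyphenyl in place of 4-chlorophenyl on a nitrogen on an aromatic ring, and an at least 1.1-fold higher number from compound 1 to compound 3 (0.06 log units; that floor lies within the scatter) with hydroxy in place of fluoro on an aromatic carbon. On these data alone, the earlier pair held only halogen-bearing aryl groups on this nitrogen, whereas the series now includes an aryl group with a hydrogen-bond donor there, and it brings no lower number; how far the true value lies past the limit is unknown, so a real rise can be neither claimed nor excluded.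

The compounds shown leave open whether any change on this nitrogen moves the number beyond the scatter in either direction. As far as these compounds go, whether an amine or a carboxylic acid on the aryl ring, or a longer chain on the nitrogen in place of the aryl group, would give a lower number also remains open.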